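A few compounds are considered here, and "the series" means these few. Any claim that something is new, unique, unknown or untested is made for them only; others in the source may bear on it.

Compound 1 `O=C(O)CCCCC(CCSC(=O)c1ccccc1)SC(=O)c1ccccc1`: 81%
Compound 2 `O=C(CCCCC1CCSS1)Nc1cccc(C(F)(F)F)c1`: 61.9%
Compound 3 `O=C(CCCCC1CCSS1)Nc1ccc([N+](=O)[O-])c(C(F)(F)F)c1`: 23.9%

All three numbers come from a functional assay on Bel-7402 cells (Homo sapiens) for inhibition, read by MTT assay, with a stated time of 24 h, tested at 100 ug/mL (a lower number here means less inhibition of growth, a higher number more inhibition of growth at the concentration tested), and the starting point here is compound 2, which sits in the middle at 61.9% with compound 1 higher and compound 3 lower, both gaps beyond the scatter.

Compound 4 `O=C(CCCCC(S)CCS)Nc1cccc(C(F)(F)F)c1` has not been measured yet. It differs from compound 2 by a group of 5 heavy atoms (3 carbon, 2 sulfur; no ring) in place of a group of 5 heavy atoms (3 carbon, 2 sulfur; one five-membered non-aromatic ring with 2 hetero atoms), on a saturated chain carbon, four bonds along the chain from a carbonyl carbon so the five-membered non-aromatic ring gives way to a 1,3-disulfanylpropyl group with no ring.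

Within the data shown here, only one measured step exists, a number 38 percentage points lower from compound 2 to compound 3 (beyond the scatter) and it is large. That step places nitro in place of hydrogen on an aromatic carbon, a different part of the molecule, so it does not indicate a direction for this change. Among the measured compounds shown here, it shows only that a single change can move the number far in this small set. Compound 1 also lacks the ring and gives 81% in this assay but it differs from compound 4 in other places too, which makes it only a weak hint of a rise.

A small rise is therefore expected, estimated as a number 6.1 percentage points higher from compound 2 to compound 4 (within the scatter) and perhaps no real change at all. For compound 4 the estimate is 68% with an expected range from 42% to 90% in this assay.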

Compound 4, percent growth inhibition at one concentration: 25.3%
Beside the measured number, compound 4's estimate is 42.7 percentage points above it; measured number below the stated range.
By their numbers in this assay, from the lowest: compounds 3 and 4 (each within the scatter of the next); then compound 2; then compound 1.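

Opening the five-membered non-aromatic ring of compound 2 into a 1,3-disulfanylpropyl group is not a neutral swap in this assay, since a number 36.6 percentage points lower from compound 2 to compound 4 (beyond the scatter) is the result of this one change. The saturated chain carbon, four bonds along the chain from a carbonyl carbon, therefore joins the aromatic carbon of a number 38 percentage points lower from compound 2 to compound 3 (beyond the scatter) as a second place where a single change gives a large step from compound 2. The two groups hold the same heavy atoms, while the entering one counts 2 hydrogen-bond donors and the leaving one 0, so keeping those atoms is not enough to keep the number, and the higher value of compound 1, which also lacks the ring, cannot be read as a result of opening it.

Still open, going by these compounds, is what this amide would give with the two sulfur atoms capped as benzoyl thioesters, as in compound 1, or held in a six-membered ring. No measurement here explains why the number falls when the ring opens.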